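A few compounds are considered here, and "the series" means these few. Any claim that something is new, unique, unknown or untested is made for them only; others in the source may bear on it.

Measured in a functional assay on A549 cells (Homo sapiens) for cytotoxicity, read by MTT assay, with a stated time of 48 h; on this read-out lower numbers stand for stronger inhibition and higher numbers for weaker inhibition:
- Compound 1 `CCCCNCCOc1c(O)cc(O)c2c(=O)cc(-c3ccccc3)oc12`: "not determined" (no result reported)
- Compound 2 `COc1c(OCCCCN2CCNCC2)cc(O)c2c(=O)cc(-c3ccccc3)oc12`: 1740 nM
- Compound 3 `CCN(CC)CCCOc1c(O)cc(O)c2c(=O)cc(-c3ccccc3)oc12`: > 100000 nM

Within the data shown here, compound 2 holds the only true number in this small set, 1740 nM. Compound 3 gives > 100000 nM, which is a limit of the assay and not a number. Among the measured compounds shown here, compound 1 has no result, and no two measured compounds differ in just one place, so no measured step is available as a guide.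

The next compound is compound 4 `COc1c(OCc2ncc(C)o2)cc(O)c2c(=O)cc(-c3ccccc3)oc12`, which is compared here with compound 2. The change is 5-methyl-1,3-oxazol-2-yl in place of 3-(piperazin-1-yl)propyl on a saturated chain carbon bound to an oxygen on an aromatic ring. A six-membered non-aromatic ring leaves, and a five-membered aromatic ring enters.

For the measured compounds named here, the expectation starts from compound 2 at 1740 nM, the one number available, and this compound loses its piperazine ring in the change. Compound 3, with a different chain, shows only the limit > 100000 nM, so a number in this range is not assured for other chains. In this assay, the expected change is a 10-fold higher number from compound 2 to compound 4 (1.01 log units; beyond the scatter), toward weaker inhibition and beyond the usual scatter. Compound 4 is expected at about 18000 nM, with an estimated range of 4000 nM to 80000 nM.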

Compound 4, half-maximal inhibitory concentration: > 100000 nM
Compound 4: only a limit was reported (the forecaster's own chance of this, stated with the estimate: 30%); middle value at least 5.5-fold (0.74 log units) away from the limit.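

Among these compounds, the change from the 4-(piperazin-1-yl)butyl group to the (5-methyl-1,3-oxazol-2-yl)methyl group, on the oxygen on an aromatic ring, gives the first readable step in this set: in this assay there is an at least 57-fold higher number from compound 2 to compound 4 (1.75 log units; beyond the scatter). This shows that the group at this position can decide whether the compound gives a measurable number in this assay at all, since the shared core alone does not keep the activity seen with the piperazine chain. In this assay compound 4 gives > 100000 nM, which is a limit of the assay and not a number, and the true size of the step stays unknown because the reading stops at that limit: the limit of > 100000 nM in this assay, at which 2 of the 4 values shown sit.

The step replaces the ring and the length of the chain at once, so it cannot tell whether the loss of the piperazine ring or the shorter link to the ring matters more. The same chain ending in a morpholine ring or a dimethylamino group, or the 5-methyl-1,3-oxazol-2-yl ring on a longer chain, would pull these two parts apart.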